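Carbamate in place of the free hydroxyl of compound 1

This account rests on a few compounds, and the source may have more. Where it says the series, first, only, none or still open, it means among the compounds named here.

Compound 1 `OC1CCN(c2ccc(-c3ccccc3Cl)nn2)CC1` is assessed in a functional assay on the whole organism with Mus musculus as the target (a higher number here means that more compound is needed for the effect, a lower number that less compound is needed), where compound 1 gives 38 mg/kg. Among the three compounds with numbers, compound 1 stands second highest: compound 3 `OC1CCN(c2ccc(-c3ccccc3F)nn2)CC1` gives 30 mg/kg, within the scatter of compound 1, while compound 2 `OC1CCN(c2ccc(-c3cc(Cl)ccc3Cl)nn2)CC1` gives 131 mg/kg. Both measured steps concern the aromatic ring: a 3.4-fold higher number from compound 1 to compound 2 (0.54 log units; beyond the scatter), and a 1.3-fold lower number from compound 1 to compound 3 (0.10 log units; within the scatter).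

Compound 4 `CN(C)C(=O)OC1CCN(c2ccc(-c3ccccc3Cl)nn2)CC1` differs from compound 1 at the other end of the molecule: dimethylcarbamoyl in place of hydrogen on an oxygen on a saturated carbon. Going by the values given here, neither measured step touches the oxygen on the saturated carbon, so no step bears directly on this change, and the series so far gives no guide to its size or direction. The expectation for compound 4 is therefore placed near compound 1, with a wide range to reflect that. The expected step is a 1.3-fold higher number from compound 1 to compound 4 (0.12 log units; within the scatter). Compound 4 is expected to give 50 mg/kg in this assay, with a range from 20 mg/kg to 130 mg/kg.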

Compound 4, dose for half-maximal effect: 1.6 mg/kg
Compound 4: the middle estimate sits 31-fold (1.49 log units) above what was measured; measured number below the stated range.
By their numbers in this assay, from the lowest: compound 4; then compounds 3 and 1 (each within the scatter of the next); then compound 2.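

In this assay the change from hydroxy to (dimethylcarbamoyl)oxy gives a 24-fold lower number from compound 1 to compound 4 (1.38 log units; beyond the scatter) and is the largest step in the series, well ahead of a 3.4-fold higher number from compound 1 to compound 2 (0.54 log units; beyond the scatter) on the aromatic ring and opposite to it in direction. Going by these compounds alone, the oxygen on the saturated carbon is therefore a far more responsive place than the earlier compounds could show, and the free hydroxyl is not required for a low number here. Nothing at hand accounts for the size of this step.

The compounds shown leave open whether the gain belongs to dimethylcarbamoyl specifically or would also appear with an acetyl ester, a methyl ether or a diethylcarbamoyl group on this oxygen. Also open, going by these compounds, is whether the same change carries over to compound 2 and compound 3.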